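From 2-chlorophenyl to naphthalen-1-yl on the shared core

A few compounds are considered here, and "the series" means these few. Any claim that something is new, unique, unknown or untested is made for them only; others in the source may bear on it.

Compound 1 `O=C(CSc1nncnc1-c1cccc2ccccc12)Nc1ccccc1Cl`: 63000 nM
Compound 2 `O=C(CSc1nncnc1-c1ccccc1Cl)N1CCc2ccccc2C1`: >= 38000 nM (a limit)

Both compounds were tested in an ADME assay on MT4 cells (Homo sapiens) for cytotoxicity, read by MTT assay; on this read-out higher numbers stand for lower toxicity in this test and lower numbers for higher toxicity in this test. Compound 2 stands at >= 38000 nM, which is a limit of the assay and not a number. Compound 1 gives a measured number, 63000 nM.

Compound 3 `O=C(CSc1nncnc1-c1cccc2ccccc12)N1CCc2ccccc2C1` has not yet been measured. It differs from compound 2 in one place, where naphthalen-1-yl stands in place of 2-chlorophenyl on an aromatic carbon: naphthalen-1-yl in place of 2-chlorophenyl on an aromatic carbon. Within the data shown here, no measured pair of compounds shows this change on its own. Among the measured compounds shown here, the only guide is compound 1, which carries the same naphthalen-1-yl and gives 63000 nM in this assay. On that basis, no step beyond the usual scatter is expected, and neither direction is favoured. The estimated change is a step that the limit leaves unreadable from compound 2 to compound 3. Compound 3 is expected to give about 50000 nM, with an estimated range from 22000 nM to 100000 nM, and the assay may report only a limit.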

Compound 3, half-maximal cytotoxic concentration: 13000 nM
The estimate for compound 3 lay 3.8-fold (0.59 log units) above the measured number, outside the stated range (below it).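

Naphthalen-1-yl in place of 2-chlorophenyl on an aromatic carbon of the shared core gives, in this assay, an at least 2.9-fold lower number from compound 2 to compound 3 (0.46 log units; beyond the scatter) with 1,2,3,4-tetrahydroisoquinolin-2-yl on the carbonyl carbon, so this change at this place registers in the test. That step starts from compound 2, whose value is a limit of the assay and not a number: the limit of >= 38000 nM in this assay, at which 1 of the 3 values shown sits. With naphthalen-1-yl held constant, 1,2,3,4-tetrahydroisoquinolin-2-yl in place of (2-chlorophenyl)amino on a carbonyl carbon gives a 4.8-fold lower number from compound 1 to compound 3 (0.69 log units; beyond the scatter) and so higher toxicity in this test, which shows that the value of compound 1 did not carry over to a compound with a different group on the carbonyl carbon.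

The full size of the step from 2-chlorophenyl to naphthalen-1-yl stays open, and the compounds shown do not tell whether it would look the same with (2-chlorophenyl)amino on the carbonyl carbon. They also leave open what a plain phenyl ring, a pyridinyl ring or an amine at this aromatic carbon would give in this assay on the shared core.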